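Trimming a Dipentylamino Group in a Cytotoxicity Series

The compounds below may be only part of what the source reports. "The series", "measured", "known", "first", "only" and "open" are said of these compounds alone.

Three compounds sharing one fused core have been tested in a functional assay on HepG2 cells (Homo sapiens) for cytotoxicity, read by MTT assay, with a stated time of 72 h; a lower number here means a stronger inhibitor, a higher number a weaker inhibitor:

Compound 1 `CC(C)N(c1nc2c(ncn2-c2ccccc2)c(=O)n1-c1ccccc1)C(C)C` gives > 100000 nM, which is a limit of the assay rather than a number.
Compound 2 `CCCCCN(CCCCC)c1nc2c(ncn2-c2ccccc2)c(=O)n1-c1ccc(Cl)cc1` gives > 100000 nM, again a limit of the assay.
Compound 3 `CCNc1nc2c(ncn2-c2ccccc2)c(=O)n1-c1ccccc1` gives > 100000 nM, likewise a limit of the assay.

Compound 2 therefore stands where every measured compound stands: at the limit of > 100000 nM in this assay, at which 3 of the 3 values shown sit. For the measured compounds named here, the one comparison of two compounds differing in a single place, a step that the two limits leave unreadable from compound 1 to compound 3, cannot be read as a size, since both ends are limits. So no measured step shows how changing the amino group on this core moves cytotoxicity.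

Compound 4 `CCCCNc1nc2c(ncn2-c2ccccc2)c(=O)n1-c1ccc(Cl)cc1` is the next compound to be measured. It differs from compound 2 by butylamino in place of dipentylamino on an aromatic carbon. With no readable step available, the expectation for compound 4 in this assay rests only on the fact that all three measured compounds sit at the limit, and it is expected to do the same, with the step from compound 2 estimated as a step that the limit leaves unreadable from compound 2 to compound 4. Compound 4 is thus estimated at 150000 nM, within a range from 40000 nM to 600000 nM.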

Compound 4, half-maximal inhibitory concentration: 77600 nM
Compound 4: middle estimate off by 1.9-fold (0.29 log units), on the high side; the range from low to high includes it.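

In this assay, for the compounds shown here, compound 4 is the first compound on the shared core to give a number rather than a limit, so the amino position between two ring nitrogen atoms can now be tied to at least one readable result. Replacing dipentylamino with butylamino, which also brings in a hydrogen-bond donor, gives an at least 1.2-fold lower number from compound 2 to compound 4 (0.11 log units; that floor lies within the scatter). Compound 2 gives only a limit, so this step is a floor and the real step may be larger, and that limit is the one shared by most of the compounds: the limit of > 100000 nM in this assay, at which 3 of the 4 values shown sit.

Still open, from the compounds shown here alone, is which part of the change matters: the shorter chains, the loss of one chain, or the hydrogen-bond donor that enters. A pentylamino or dibutylamino group at this position would help separate these, while a ring amine such as morpholine would test a different shape of amine.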